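A few compounds are considered here, and "the series" means these few. Any claim that something is new, unique, unknown or untested is made for them only; others in the source may bear on it.

Measured so far in a functional assay on MDA-MB-231 cells (Homo sapiens) for inhibition, read by MTT assay, with a stated time of 72 h; on this read-out higher numbers stand for weaker inhibition and lower numbers for stronger inhibition:
compound 1 `O=C1C[C@H]2O[C@H](C(O)O)[C@H](O)[C@H]2O1`: 58700 nM
compound 2 `O=C1C[C@H]2O[C@H]([C@H](O)c3ccccc3)[C@H](O)[C@H]2O1`: 75300 nM
compound 3 `CO[C@@H]1[C@H]2OC(=O)C[C@H]2O[C@@H]1[C@H](O)c1ccccc1`: 28600 nM

Compound 2 carries the highest of the three numbers; its gap to compound 1 is within the scatter, so those two cannot be told apart, while compound 3 sits clearly lower. One step among the measured compounds is a methylation of a hydroxy group: a 2.6-fold lower number from compound 2 to compound 3 (0.42 log units; beyond the scatter), a modest but real move toward stronger inhibition.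

Compound 4 `CO[C@H](c1ccccc1)[C@H]1O[C@@H]2CC(=O)O[C@@H]2[C@H]1O` is the other methyl ether of compound 2. methyl in place of hydrogen on an oxygen on a saturated carbon The oxygen that takes the methyl is on a saturated carbon whose other neighbours are a saturated chain carbon, so the change is the same kind as before, but at a different oxygen. Within the data shown here, only the step from compound 2 to compound 3 bears on it, and how far a result at one oxygen carries over to the other is not known. The expectation is a lowering of similar or smaller size, with no change beyond the scatter also possible. Compound 4 is therefore estimated at 45000 nM, with a range of 20000 nM to 100000 nM. This amounts to an expected 1.7-fold lower number from compound 2 to compound 4 (0.22 log units; within the scatter).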

Compound 4, half-maximal inhibitory concentration: 64 nM
Beside the measured number, compound 4's estimate is 700-fold (2.85 log units) above it; the measured number lies below the stated range.
By their numbers in this assay, from the lowest: compound 4; then compound 3; then compounds 1 and 2 (each within the scatter of the next).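

Working from the parent compound 2 in this assay, hydroxy to methoxy on this oxygen gives a 1200-fold lower number from compound 2 to compound 4 (3.07 log units; beyond the scatter) and stands as the large step in the series, whereas the same exchange at the other oxygen gave a 2.6-fold lower number from compound 2 to compound 3 (0.42 log units; beyond the scatter) and stayed modest. The response to this methyl therefore depends strongly on which oxygen carries it, and the result at one oxygen gives no reliable measure of the result at the other. No measurement at hand accounts for the difference in size between the two steps.

Going by these compounds, it remains open whether this large step is specific to the methyl, or whether an ethyl ether, a longer chain or an amine at this place would keep it. On these data alone, the effect of methyl on both oxygens together also remains open.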